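This account rests on a few compounds, and the source may have more. Where it says the series, first, only, none or still open, it means among the compounds named here.

Two compounds built on one shared core, compound 1 `O[C@H]1C[C@@H](Cn2cnc3c(-c4ccccc4)ncnc32)c2ccccc21` and compound 2 `COc1ccccc1-c1ncnc2c1ncn2C[C@@H]1C[C@H](O)c2ccccc21`, were tested in an ADME assay on L1210/0 cells (Mus musculus) for cytotoxicity, with a stated time of 48 h; a lower number here means a stronger inhibitor, a higher number a weaker inhibitor. In this assay compound 2 gives only a limit of the assay and not a number, > 200000 nM. Compound 1 likewise gives only a limit of the assay, > 200000 nM. The change between them is hydrogen in place of methoxy on an aromatic carbon, and the resulting step, a step that the two limits leave unreadable from compound 2 to compound 1, cannot be read, because both values sit at the limit of > 200000 nM in this assay, at which 2 of the 3 values shown sit.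

Compound 3 `COc1ccc(C(=O)/C=C/c2cc(=O)[nH]c(=O)n2COCCO)cc1` rests on a different core; the difference between the two cores is not broken down here. In this assay compound 3 gives 33500 nM. Compound 4 `O=C(/C=C/c1cc(=O)[nH]c(=O)n1COCCO)c1ccccc1` differs from compound 3 by hydrogen in place of methoxy on an aromatic carbon. This is the same kind of change as that from compound 2 to compound 1, but around the place it differs: there the hydrogen enters ortho to a large group, here para to a large group. Since the earlier step is unreadable, the expected step from compound 3 to compound 4 is set small, a 1.2-fold higher number from compound 3 to compound 4 (0.08 log units; within the scatter), and compound 4 is estimated at 40000 nM, between 15000 nM and 120000 nM.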

Compound 4, half-maximal inhibitory concentration: 43300 nM
Compound 4: the middle estimate sits 1.1-fold (0.03 log units) below what was measured; low and high end bracket the measured number.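

In this assay, hydrogen in place of methoxy, para to a large group, gives a 1.3-fold higher number from compound 3 to compound 4 (0.11 log units; within the scatter), so on this core compound 3 and compound 4 cannot be told apart. The same change on the other core cannot be read, because compound 2 and compound 1 each give only a limit of the assay and not a number: the limit of > 200000 nM in this assay, at which 2 of the 4 values shown sit. This leaves a single readable case of the change, which shows that it makes no measurable difference on the core of compound 3, but does not show whether it would behave the same way on the core of compound 1.

Still open, on these data alone, is whether a different group at the same place on the phenyl ring of compound 4, such as an amine, a carboxylic acid or a longer ethoxy chain, would move the number beyond the scatter. Also open, as far as these compounds go, is whether any such group would bring compound 1 from a limit to a readable number.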